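The source may hold more compounds than are shown below. What is called first, only, known or untested is meant among the compounds shown, and "the series" means these compounds.

Measured to date in an assay on a protein complex for inhibition of CDK8/Cyclin C (Homo sapiens), with a stated time of 1 h, tested at 10 uM; on this read-out higher numbers stand for more inhibition at the one concentration tested (going by the name of the read-out) and lower numbers for less inhibition:
compound 1 `CCOC(=O)/C=C/c1ccncc1-c1ccc2ccccc2c1` gives 102%;
compound 2 `CNC(=O)CCc1ccncc1-c1ccc2ccccc2c1` gives 100%;
compound 3 `COC1CN(C(=O)/C=C/c2ccncc2-c2ccc3ccccc3c2)C1` gives 100%.

Compound 3 stands level with compound 2 at the digits reported and nearest to it, with compound 1 furthest away; all three lie within the scatter of one another. The step to compound 4 `CN(C)C(=O)/C=C/c1ccncc1-c1ccc2ccccc2c1` is dimethylamino in place of 3-methoxyazetidin-1-yl on a carbonyl carbon. For the measured compounds named here, two measured steps bear on it: a number 2 percentage points lower from compound 1 to compound 3 (within the scatter), which changes the same carbonyl carbon, and a number 2 percentage points lower from compound 1 to compound 2 (within the scatter), a broader change of the same substituent. Neither moved the read-out beyond the scatter, so in this assay no step beyond the scatter is expected for compound 4: a number 1 percentage points lower from compound 3 to compound 4 (within the scatter). Compound 4 is accordingly estimated at 99%, within 88% to 106%.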

Compound 4, a percentage reported as inhibition, at one concentration (the size of the read-out at that concentration, not a potency): 100%
For compound 4 the middle estimate is 1 percentage points below the measured one; the measured number falls inside the stated range.
By their numbers in this assay, from the lowest: compounds 2, 3, 4 and 1 (each within the scatter of the next).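

On the carbonyl carbon, dimethylamino, with no ring, replaces 3-methoxyazetidin-1-yl with no change at the digits printed from compound 3 to compound 4 (within the scatter) in this assay, so neither the four-membered ring nor its oxygen is required for this read-out at the one concentration tested. Replacing ethoxy with dimethylamino gives a number 2 percentage points lower from compound 1 to compound 4 (within the scatter) and replacing 2-(methylcarbamoyl)ethyl with 2-(dimethylcarbamoyl)ethenyl gives no change at the digits printed from compound 2 to compound 4 (within the scatter), so all four groups at this position read alike. For the compounds shown here, no evidence accompanies these steps.

On these data alone, whether a carboxylic acid or a longer chain on this carbonyl carbon would separate from these compounds remains open. Single-concentration numbers give no potency ranking among the four compounds.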